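Swapping the aromatic ring for an ethoxycarbonyl chain

The source may report more compounds than this note shows. Statements on the series, on what has been measured and on what is new or still open speak of the compounds shown alone.

Three compounds share one core and differ only in the group on a saturated chain carbon bound to an aromatic nitrogen. In an assay on isolated protein (Oryctolagus cuniculus) with Thromboxane-A synthase (Homo sapiens) as the target, tested at 1 uM (a higher number here means more inhibition at the concentration tested (going by the name of the read-out), a lower number less inhibition), compound 3 `O=c1c2ccccc2c(-c2cccnc2)nn1Cc1cccc(Cl)c1` gives 95%, the second highest of the three numbers; compound 2 `O=c1c2ccccc2c(-c2cccnc2)nn1Cc1ccccc1` gives 97% and compound 1 `CC(C)=CCn1nc(-c2cccnc2)c2ccccc2c1=O` gives 94%. All three lie within the scatter of one another: a number 2 percentage points lower from compound 2 to compound 3 (within the scatter), a number 1 percentage points higher from compound 1 to compound 3 (within the scatter), a number 3 percentage points higher from compound 1 to compound 2 (within the scatter). Compound 4 `CCOC(=O)CCCn1nc(-c2cccnc2)c2ccccc2c1=O` carries 2-(ethoxycarbonyl)ethyl in place of 3-chlorophenyl on a saturated chain carbon bound to an aromatic nitrogen. Going by the values given here, no measured step replaces an aromatic ring with an ethoxycarbonyl chain, but compound 1 shows that a non-aromatic chain at this place also gives a high number, 94%. Compound 4 is therefore expected to give 91%, between 78% and 98%. That estimate means a number 4 percentage points lower from compound 3 to compound 4 (within the scatter), so no step beyond the scatter is expected.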

Compound 4, a percentage reported as inhibition, at one concentration (the size of the read-out at that concentration, not a potency): 95%
Compound 4: the middle estimate sits 4 percentage points below what was measured; measured number inside the range.
By their numbers in this assay, from the lowest: compounds 1, 3, 4 and 2 (each within the scatter of the next).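

The 2-(ethoxycarbonyl)ethyl group has no ring and, unlike the 3-chlorophenyl it replaces, carries hydrogen-bond acceptors, yet in this assay the result is no change at the digits printed from compound 3 to compound 4 (within the scatter), a number 2 percentage points lower from compound 2 to compound 4 (within the scatter) and a number 1 percentage points higher from compound 1 to compound 4 (within the scatter). This position on a saturated chain carbon bound to an aromatic nitrogen therefore accepts an ester chain as well as the earlier groups. Nothing available explains why these numbers stay alike.

On these data alone, whether a carboxylic acid or an amine on this chain, or a longer chain, would also keep the number high remains open. So does whether these four compounds would separate at a lower concentration.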